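Swapping the diazo group for chloromethyl on two related ketones

The source may report more compounds than this note shows. Statements on the series, on what has been measured and on what is new or still open speak of the compounds shown alone.

Measured so far:
compound 1, `CC(=O)N[C@@H](CSCC=C(C)C)C(=O)C=[N+]=[N-]`, > 100000 nM
compound 2, `CCCCCCCCCCCCSC[C@H](NC(C)=O)C(=O)C=[N+]=[N-]`, 22900 nM
compound 3, `CC(=O)N[C@@H](CSCC=C(C)C)C(=O)CCl`, 7900 nM

All three share an acetylated amino-ketone built on a sulfur-linked side chain, and all were tested in a functional assay on MOLT-3 cells (Homo sapiens); a higher number here means a weaker inhibitor, a lower number a stronger inhibitor. For compound 1 the value is not a number but a limit of the assay, > 100000 nM. Compound 3 differs from compound 1 by a group of 2 heavy atoms (1 carbon, 1 chlorine; no ring) in place of a group of 3 heavy atoms (1 carbon, 2 nitrogen; no ring), on a carbonyl carbon. In this assay compound 3 gives 7900 nM, a step of an at least 12-fold lower number from compound 1 to compound 3 (1.10 log units; beyond the scatter). The size of that step is only known as a floor, since it rests on (the limit of > 100000 nM in this assay, at which 1 of the 3 values shown sits).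

Compound 2 carries a different side chain, and the difference between its core and that of compound 1 is not broken down here. In this assay compound 2 gives 22900 nM, the highest of the two numbers, with compound 3 nearest at a step beyond the scatter.

Compound 4, `CCCCCCCCCCCCSC[C@H](NC(C)=O)C(=O)CCl`, is not yet measured. It differs from compound 2 by a group of 2 heavy atoms (1 carbon, 1 chlorine; no ring) in place of a group of 3 heavy atoms (1 carbon, 2 nitrogen; no ring), on a carbonyl carbon, the same change as from compound 1 to compound 3, made on the same kind of carbonyl carbon. Going by these compounds, from that earlier step, which is large, compound 4 is expected to show a step of a 15-fold lower number from compound 2 to compound 4 (1.18 log units; beyond the scatter) in this assay, though the exact size of the earlier step is unknown. Compound 4 is therefore estimated at 1500 nM, with a range from 300 nM to 8000 nM.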

Compound 4, half-maximal inhibitory concentration: 2300 nM
Beside the measured number, compound 4's estimate is 1.5-fold (0.19 log units) below it; the measured number falls inside the stated range.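

In this assay, putting chloromethyl in place of the diazo group on the carbonyl carbon gives a 10-fold lower number from compound 2 to compound 4 (1.00 log units; beyond the scatter). The change therefore lowers the number on both cores, and on each the step lies beyond the scatter: the same change on two cores in this assay, an at least 12-fold lower number (1.10 log units; beyond the scatter) from compound 1 to compound 3 and a 10-fold lower number (1.00 log units; beyond the scatter) from compound 2 to compound 4; the limit leaves it open whether they differ. This does not show that the step has the same size on the two cores, and two pairs do not make a rule for other cores in the series; compound 1 sits at a limit of the assay and not at a number: the limit of > 100000 nM in this assay, at which 1 of the 4 values shown sits.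

The compounds shown leave open whether the lower numbers depend on chloromethyl in particular, or whether another group on the same carbonyl carbon, such as bromomethyl or fluoromethyl, would give a similar step. They also leave open how the same change behaves with other side chains on the sulfur, such as a chain of intermediate length or one carrying an amine or a carboxylic acid.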